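Benzyl in Place of 2,4-Dimethylphenyl on the Aromatic Nitrogen

The source may hold more compounds than are shown below. What is called first, only, known or untested is meant among the compounds shown, and "the series" means these compounds.

Measured compounds:
compound 1 `Cc1ccc(-n2cc(CNC(=O)c3cccc4c3cnn4C(C)C)nn2)c(C)c1` — > 40000 nM
compound 2 `COc1ccc(-n2cc(CNC(=O)c3cccc4c3cnn4C(C)C)nn2)cc1` — > 40000 nM

In a functional assay on MGC-803 cells (Homo sapiens) for inhibition, read by MTT assay, with a stated time of 72 h (a lower number here means a stronger inhibitor, a higher number a weaker inhibitor), compound 1 gives only a limit of the assay, > 40000 nM. Compound 2 likewise gives only a limit, > 40000 nM. The step that the two limits leave unreadable from compound 1 to compound 2 is therefore unreadable, which matches (the limit of > 40000 nM in this assay, at which 2 of the 2 values shown sit). Compound 3 `CC(C)n1ncc2c(C(=O)NCc3cn(Cc4ccccc4)nn3)cccc21` differs from compound 1 by benzyl in place of 2,4-dimethylphenyl on an aromatic nitrogen. For the measured compounds named here, no measured step bears on this change, and with both values shown as limits no size or direction can be expected beyond the scatter. Compound 3 is therefore estimated at 40000 nM, within 10000 nM to 120000 nM. That estimate means an expected step of a number no higher from compound 1 to compound 3 (the limit leaves the size open).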

Compound 3, half-maximal inhibitory concentration: 14300 nM
The estimate for compound 3 lay 2.8-fold (0.45 log units) above the measured number; low and high end bracket the measured number.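

In this assay, for the compounds shown here, benzyl on the aromatic nitrogen gives the only value shown that is a number rather than a limit, with an at least 2.7-fold lower number from compound 1 to compound 3 (0.44 log units; beyond the scatter) and an at least 2.7-fold lower number from compound 2 to compound 3 (0.44 log units; beyond the scatter). This shows that the position responds to the group it carries, which the 2,4-dimethylphenyl and 4-methoxyphenyl groups of compound 1 and compound 2 could not show. As far as these compounds go, the true size of both steps stays open, and only their lower bound can be read: the limit of > 40000 nM in this assay, at which 2 of the 3 values shown sit.

From the compounds shown here alone, whether a longer chain such as phenethyl would lower the number further remains open. So does the effect of an amine or a carboxylic acid on the benzyl ring.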